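The compounds below may be only part of what the source reports. "The series", "measured", "known", "first", "only" and "open" are said of these compounds alone.

Three compounds from one series have been examined in an assay on HEK293 cells for inhibition of prostaglandin E2 receptor EP4 subtype (Rattus norvegicus); a lower number here means a stronger inhibitor, a higher number a weaker inhibitor. Compound 1 `CCCCc1ccc(CN(Cc2ccccc2OCC(=O)O)S(C)(=O)=O)cc1` carries a methylsulfonyl group on its sulfonamide nitrogen; in this assay compound 1 returned only a limit, > 3200 nM. Compound 2 `CC(C)(C)c1ccc(CN(Cc2cccc(OCC(=O)O)c2)S(C)(=O)=O)cc1`, also a methylsulfonyl compound, likewise gave only a limit, > 3200 nM. Compound 3 `CC(C)(C)c1ccc(CN(Cc2cccc(CCC(=O)O)c2)S(=O)(=O)c2nccs2)cc1`, which instead bears a (1,3-thiazol-2-yl)sulfonyl group, produced only a limit as well, > 3200 nM. So where compound 3 stands cannot be told from these numbers: none of the three readings is a true value, and all three sit together at the limit of > 3200 nM in this assay, at which 3 of the 3 values shown sit.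

Compound 4 `CC(C)(C)c1ccc(CN(Cc2cccc(CCC(=O)O)c2)S(C)(=O)=O)cc1` has not yet been measured. It differs from compound 3 in one place: methyl in place of 1,3-thiazol-2-yl on a sulfonyl sulfur. Going by the values given here, no pair of measured compounds that differ in a single place exists here, so the size of this change has never been seen directly. What is known is that compounds 1 and 2, both already methylsulfonyl compounds, gave only limits. The step that the limit leaves unreadable from compound 3 to compound 4 is therefore expected to be none beyond the usual scatter, with a limit the most likely outcome once more. Compound 4 is estimated at 6000 nM, between 2500 nM and 20000 nM.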

Compound 4, half-maximal inhibitory concentration: > 3200 nM
Compound 4 ended at the assay's limit; the forecaster's own chance of this, stated with the estimate: 75%; the middle value does not contradict the limit.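

In this assay compound 4 gave only a limit, > 3200 nM. No step from compound 3 or compound 2 to compound 4 can be read, because every reading is a limit: the limit of > 3200 nM in this assay, at which 4 of the 4 values shown sit.

The compounds shown leave open how strongly any of them truly inhibits, and whether either single change alters that at all.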